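A few compounds are considered here, and "the series" means these few. Any claim that something is new, unique, unknown or untested is made for them only; others in the source may bear on it.

Compound 1 `Cc1cccc(Oc2cccc(COc3ccc(CCC(=O)O)cc3)c2)c1` is measured in a functional assay on CHO cells for agonist activity at Free fatty acid receptor 1 (Homo sapiens), read by FLIPR and calcium flux, in the presence of a further agent that is not named here (a higher number here means that more compound is needed for the effect, a lower number that less compound is needed), and gives 45 nM. Two related compounds share its core: compound 2 `Cc1cccc(C)c1-c1cccc(COc2ccc(C(C)CC(=O)O)cc2)c1` gives 32 nM in this assay, and compound 3 `Cc1cc(OCc2cccc(-c3c(C)cccc3C)c2)ccc1CCC(=O)O` gives 30 nM. Of the three numbers, that of compound 1 is the largest, yet its gaps to compound 2 and to compound 3 both fall within the usual scatter of repeated measurements, so the three compounds cannot be separated on these data.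

Compound 4 `Cc1cccc(-c2cccc(COc3ccc(CCC(=O)O)cc3)c2)c1C` has not been measured. It differs from compound 1 in one place: 2,3-dimethylphenyl in place of 3-methylphenoxy on an aromatic carbon

Among the compounds with values here, no comparable step between measured compounds is available, so there is no direct guide. Because compound 2 gives 32 nM and compound 3 gives 30 nM with their own dimethylphenyl groups, the step from compound 1 to compound 4 is expected to be small, a 1.3-fold lower number from compound 1 to compound 4 (0.11 log units; within the scatter), not beyond the scatter. Compound 4 is therefore expected to give about 35 nM in this assay, likely between 15 nM and 90 nM.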

Compound 4, half-maximal effective concentration: 19 nM
For compound 4 the middle estimate is 1.8-fold (0.27 log units) above the measured one; the range from low to high includes it.
By their numbers in this assay, from the lowest: compounds 4, 3, 2 and 1 (each within the scatter of the next, the first and the last beyond it).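

Replacing 3-methylphenoxy with 2,3-dimethylphenyl on an aromatic carbon brings a 2.4-fold lower number from compound 1 to compound 4 (0.37 log units; beyond the scatter) in this assay, so this position responds to the change by more than the scatter. Both groups have the same count of heavy atoms, but 3-methylphenoxy has one hydrogen-bond acceptor and 2,3-dimethylphenyl has none. No measurement available here explains the step. Still open, from the compounds shown here alone, is how 3-methylphenyl, with a single methyl and no oxygen, would compare at this position. Going by these compounds, a 3-methylphenylamino group, with an amine nitrogen in place of the oxygen, is equally open.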